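The source may hold more compounds than are shown below. What is called first, only, known or untested is meant among the compounds shown, and "the series" means these compounds.

Measured in a functional assay on NCI-H322 cells (Homo sapiens) for cytotoxicity, read by MTT assay, with a stated time of 24 h (a higher number here means a weaker inhibitor, a lower number a stronger inhibitor), so far:
compound 1 `COc1ccccc1-n1cc(COc2c(/C=C\C(=O)O)ccc(OC)c2CC=C(C)C)nn1` - 41500 nM
compound 2 `COc1ccc(-n2cc(COc3c(/C=C\C(=O)O)ccc(OC)c3CC=C(C)C)nn2)cc1` - "not determined" (no result reported)
compound 3 `COc1ccc(/C=C\C(=O)O)c(OCc2cn(-c3ccccc3I)nn2)c1CC=C(C)C` - 42300 nM

Compound 3 (42300 nM) lies within the scatter of compound 1 (41500 nM), and compound 2 offers no number for comparison. Compound 4 `COc1ccc(/C=C\C(=O)O)c(OCc2cn(-c3cccnc3Cl)nn2)c1CC=C(C)C` carries 2-chloropyridin-3-yl in place of 2-iodophenyl on an aromatic nitrogen. For the measured compounds named here, no measured compound carries that group. Going by the values given here, the only measured step bearing on the change, iodo in place of methoxy on an aromatic carbon, is a 1.0-fold higher number from compound 1 to compound 3 (0.01 log units; within the scatter) and stays within the scatter. This single step is thin evidence, but no shift beyond the scatter is expected in this assay. The estimated step is a 1.1-fold lower number from compound 3 to compound 4 (0.02 log units; within the scatter) (expected to stay within the scatter). Compound 4 is expected at 40000 nM (estimated range 20000 nM to 80000 nM).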

Compound 4, half-maximal inhibitory concentration: 42200 nM
For compound 4 the middle estimate is 1.1-fold (0.02 log units) below the measured one, within the range that was stated.
By their numbers in this assay, from the lowest: compounds 1, 4 and 3 (each within the scatter of the next).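

In this assay, the ring on the aromatic nitrogen can change from carbon only to one with 1 hetero atom, with a chlorine in place of iodine, and the result is a 1.0-fold lower number from compound 3 to compound 4 (0.00 log units; within the scatter). Against the 2-methoxyphenyl group of the earlier series, the same 2-chloropyridin-3-yl group gives a 1.0-fold higher number from compound 1 to compound 4 (0.01 log units; within the scatter), so all three aryl groups now read alike at this position, including the one with a ring nitrogen. No supporting data explain this flat result. Still open, as far as these compounds go, is whether a group of another kind on this aromatic nitrogen, such as a simple alkyl chain, an amine or a carboxylic acid, would move the number beyond the scatter.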